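Methyl in place of methoxy on a weak compound

The source may hold more compounds than are shown below. What is called first, only, known or untested is meant among the compounds shown, and "the series" means these compounds.

Compound 1 `CC(C)N1C(=O)COc2ccc(-c3cccc(NS(=O)(=O)c4ccc(F)cc4)c3)cc21`: > 40000 nM
Compound 2 `COc1ccc(N2C(=O)COc3ccc(-c4cccc(NS(=O)(=O)c5ccc(F)cc5)c4)cc32)cc1`: 38500 nM

Among the compounds with values here, in a functional assay on A-375 cells (Homo sapiens) for antiproliferative activity, read by MTT assay, with a stated time of 72 h (on this read-out lower numbers stand for stronger inhibition and higher numbers for weaker inhibition), compound 2 gives 38500 nM, the only actual number so far. Compound 1 reads > 40000 nM, which is a limit of the assay. Compound 3 `Cc1ccc(N2C(=O)COc3ccc(-c4cccc(NS(=O)(=O)c5ccc(F)cc5)c4)cc32)cc1` differs from compound 2 by methyl in place of methoxy on an aromatic carbon, turning 4-methoxyphenyl into 4-methylphenyl. Within the data shown here, the one measured step bearing on this is an at least 1.0-fold lower number from compound 1 to compound 2 (0.01 log units; that floor lies within the scatter), which brings in the 4-methoxyphenyl group and stays within the scatter. No step beyond the scatter is therefore expected in this assay, and no direction is favoured. The expected step is a 1.1-fold lower number from compound 2 to compound 3 (0.04 log units; within the scatter). For compound 3 the estimated value is 35000 nM, with an expected range of 18000 nM to 60000 nM.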

Compound 3, half-maximal inhibitory concentration: 36200 nM
For compound 3 the middle estimate is 1.0-fold (0.01 log units) below the measured one, and the stated range covers the measured number.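

In this assay, methyl in place of methoxy on an aromatic carbon, para to a large group, gives a 1.1-fold lower number from compound 2 to compound 3 (0.03 log units; within the scatter), so at this position the two substituents cannot be told apart. The comparison with isopropyl gives an at least 1.1-fold lower number from compound 1 to compound 3 (0.04 log units; that floor lies within the scatter), and this floor also shows no separation beyond the scatter. The reading for compound 1 is a limit of the assay: the limit of > 40000 nM in this assay, at which 1 of the 3 values shown sits.

As far as these compounds go, how far compound 1 truly lies from compound 3 stays open. So does whether an amine or a carboxylic acid on this phenyl ring would move the number beyond the scatter.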